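Replacing (2-oxopropyl)carbonyl with 3-methyl-1H-pyrazol-5-yl

This account rests on a few compounds, and the source may have more. Where it says the series, first, only, none or still open, it means among the compounds named here.

In a functional assay on MCF7 cells (Homo sapiens) for cytotoxicity, read by MTT assay, with a stated time of 72 h (on this read-out lower numbers stand for stronger inhibition and higher numbers for weaker inhibition), compound 1 (`COc1ccc(/C=C/c2cc(C)n[nH]2)cc1`) stands at 9700 nM and compound 2 (`COc1ccc(/C=C/C(=O)CC(C)=O)cc1OC`) at 10600 nM within the scatter of compound 1, so neither can be ranked over the other. Compound 3 (`COc1ccc(/C=C/c2cc(C)n[nH]2)cc1OC`) comes from compound 2 by one change (3-methyl-1H-pyrazol-5-yl in place of (2-oxopropyl)carbonyl on a double-bonded chain carbon bound to a double-bonded chain carbon) on a double-bonded chain carbon bound to a double-bonded chain carbon. Within the data shown here, no measured pair isolates this change. Compound 1 carries the same 3-methyl-1H-pyrazol-5-yl group at 9700 nM without a gap beyond the scatter from compound 2, so the estimate stays close to both values. The expected step (a 1.1-fold lower number from compound 2 to compound 3 (0.05 log units; within the scatter)) is none beyond the scatter in either direction. In this assay the estimate for compound 3 is 9500 nM (expected range 4000 nM to 22000 nM).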

Compound 3, half-maximal inhibitory concentration: 12600 nM
Compound 3: the middle estimate sits 1.3-fold (0.12 log units) below what was measured; measured number inside the range.
By their numbers in this assay, from the lowest: compounds 1, 2 and 3 (each within the scatter of the next).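

In this assay, the exchange of (2-oxopropyl)carbonyl for 3-methyl-1H-pyrazol-5-yl on a double-bonded chain carbon bound to a double-bonded chain carbon now has a measured pair, a 1.2-fold higher number from compound 2 to compound 3 (0.08 log units; within the scatter), so the two groups cannot be told apart at this place. Methoxy in place of hydrogen on an aromatic carbon also has its pair, a 1.3-fold higher number from compound 1 to compound 3 (0.11 log units; within the scatter), and it likewise gives no separation. Nothing available here explains either step or the lack of separation.

As far as these compounds go, whether an amine or a carboxylic acid on that aromatic carbon, or a longer chain in place of 3-methyl-1H-pyrazol-5-yl, would give a step beyond the scatter remains open. With all three compounds inside the scatter of one another, the compounds shown do not yet establish which structural features this read-out responds to.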